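The source may hold more compounds than are shown below. What is called first, only, known or untested is meant among the compounds shown, and "the series" means these compounds.

Measured so far in a functional assay on HeLa cells (Homo sapiens) for antiproliferative activity, read by MTT assay, with a stated time of 72 h; a lower number here means a stronger inhibitor, a higher number a weaker inhibitor:
- compound 1 `CCNC(=O)c1cc(Oc2ccc(NC(=O)c3nn(-c4ccc(Br)cc4F)c(=O)cc3C)cc2)ccn1` gives "not active" (no number reported)
- compound 2 `CCNC(=O)c1cc(Oc2ccc(NC(=O)c3nn(-c4ccccc4C)c(=O)cc3C)cc2)ccn1` gives 27300 nM
- compound 3 `CCNC(=O)c1cc(Oc2ccc(NC(=O)c3nn(-c4cccc(F)c4)c(=O)cc3C)cc2)ccn1` gives 6870 nM

Compound 3 holds the lower of the two numbers available in this assay, and compound 1 offers no number for comparison. Next is compound 4 `CCNC(=O)c1cc(Oc2ccc(NC(=O)c3nn(-c4cccc(C(F)(F)F)c4)c(=O)cc3C)cc2)ccn1`, which keeps the shared core and differs from compound 3 in one group: trifluoromethyl in place of fluoro on an aromatic carbon. In short, trifluoromethyl stands in place of fluoro on an aromatic carbon, meta to a large group.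

Among the compounds with values here, the only measured step that bears on this change is a 4.0-fold lower number from compound 2 to compound 3 (0.60 log units; beyond the scatter), which lies beyond the scatter. That step exchanged 2-methylphenyl for 3-fluorophenyl, a different change from the present one, so it offers a rough size and no direction. Within the data shown here, no measured pair compares fluoro with trifluoromethyl. Compound 1 carries no number, so a loss of measurable activity cannot be excluded.

The expected result is therefore no change beyond the scatter, and the estimated step is a 1.2-fold higher number from compound 3 to compound 4 (0.07 log units; within the scatter), with wide uncertainty on either side. Compound 4 is expected at 8000 nM, with an estimated range of 2500 nM to 25000 nM.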

Compound 4, half-maximal inhibitory concentration: 10700 nM
The estimate for compound 4 lay 1.3-fold (0.13 log units) below the measured number, and the stated range covers the measured number.
By their numbers in this assay, from the lowest: compounds 3 and 4 (each within the scatter of the next); then compound 2.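

Exchanging fluoro for trifluoromethyl on the aromatic carbon, meta to a large group, gives a 1.6-fold higher number from compound 3 to compound 4 (0.19 log units; within the scatter) in this assay, so the two groups are not separated at this position. With a 2.6-fold lower number from compound 2 to compound 4 (0.41 log units; beyond the scatter) alongside a 4.0-fold lower number from compound 2 to compound 3 (0.60 log units; beyond the scatter), both the 3-(trifluoromethyl)phenyl and the 3-fluorophenyl compounds now stand apart from the 2-methylphenyl compound by more than the scatter, whereas a single step showed this before; compound 1 gives "not active" (no number reported) and so cannot be placed in this reading. No measured data here offer an explanation for these steps.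

The compounds shown leave open whether the separation from compound 2 follows from the identity of the group or from where it sits, as no pair keeps one group and moves it; 3-methylphenyl on the aromatic nitrogen would address that directly. Also open, going by these compounds, is how far this aromatic carbon tolerates a different kind of group, such as an amine, a carboxylic acid or a longer chain, in place of fluoro or trifluoromethyl.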